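The source may report more compounds than this note shows. Statements on the series, on what has been measured and on what is new or still open speak of the compounds shown alone.

Measured in a functional assay on HCT-116 cells (Homo sapiens) for inhibition, read by MTT assay, with a stated time of 2 days, tested at 100 uM; a higher number here means more inhibition of growth at the concentration tested, a lower number less inhibition of growth:
compound 1 `CNC(=O)c1cc(Oc2ccc3nc(NC(=O)Nc4cc(C(F)(F)F)cc(C(F)(F)F)c4)sc3c2)ccn1` gives 98.4%;
compound 2 `CNC(=O)c1cc(Oc2ccc3nc(NC(=O)c4ccc(Cl)cc4)sc3c2)ccn1` gives 80.5%;
compound 3 `CNC(=O)c1cc(Oc2ccc3nc(NC(=O)c4cccc(F)n4)sc3c2)ccn1` gives 55.5%.

Compound 2 stands second highest of the three: compound 1 sits above it by a margin beyond the scatter, compound 3 below it beyond the scatter. Compound 4 `CNC(=O)c1cc(Oc2ccc3nc(NC(=O)c4cc(Cl)cc(Cl)c4)sc3c2)ccn1` differs from compound 2 by 3,5-dichlorophenyl in place of 4-chlorophenyl on a carbonyl carbon. Among the measured compounds shown here, the only measured step at the same place is a number 25 percentage points lower from compound 2 to compound 3 (beyond the scatter), so the aryl on the carbonyl carbon can shift this assay well beyond the scatter. Compound 1, with two substituents on its phenyl, gives 98.4%, but it differs from compound 2 in more than one place, so only the two values can be set side by side. A modest rise is expected, a number 5.5 percentage points higher from compound 2 to compound 4 (within the scatter). Compound 4 is estimated at 86%, range 66% to 98%.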

Compound 4, percent growth inhibition at one concentration: 15.8%
Estimate against measurement, compound 4: 70.2 percentage points above; measured number outside the range, below it.
By their numbers in this assay, from the lowest: compound 4; then compound 3; then compound 2; then compound 1.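

In this assay, 3,5-dichlorophenyl in place of 4-chlorophenyl on the carbonyl carbon gives a number 64.7 percentage points lower from compound 2 to compound 4 (beyond the scatter), so this position responds strongly to the chlorine pattern on a phenyl, not only to a change of ring type. The same group in place of 6-fluoropyridin-2-yl gives a number 39.7 percentage points lower from compound 3 to compound 4 (beyond the scatter), so the two chlorophenyl compounds do not group together here. No evidence on hand bears on the reason for these drops. Still open, from the compounds shown here alone, is what a phenyl carrying an amine or a carboxylic acid would give at this position.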